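This account rests on a few compounds, and the source may have more. Where it says the series, first, only, none or still open, it means among the compounds named here.

Compound 1 `COc1ccc2nccc(C3CN(C4CCN(Cc5cc6ccccc6[nH]5)CC4)C(=O)O3)c2c1`: 25.1 nM
Compound 2 `COc1ccc2nccc(C3CN(C4CCN(Cc5cc6ccccc6o5)CC4)C(=O)O3)c2c1`: 1260 nM

Among the compounds with values here, in an in vitro functional assay on RBL cells for antagonist activity at C-C chemokine receptor type 8 (Homo sapiens), read by FLIPR and calcium flux (a lower number here means a stronger inhibitor, a higher number a weaker inhibitor), compound 2 stands highest of the two numbers, the single step to it being a 50-fold higher number from compound 1 to compound 2 (1.70 log units; beyond the scatter). Compound 3 `COc1ccc2nccc(C3CN(C4CCN(Cc5ccc6ccccc6c5)CC4)C(=O)O3)c2c1` differs from compound 2 by naphthalen-2-yl in place of 1-benzofuran-2-yl on a saturated chain carbon bound to an amine nitrogen in a ring. Within the data shown here, the only measured step bearing on this position is a 50-fold higher number from compound 1 to compound 2 (1.70 log units; beyond the scatter), a large loss. With no measurement of a carbon-only ring at this place, compound 3 is expected to stay close to compound 2. The expected step is a 1.3-fold higher number from compound 2 to compound 3 (0.10 log units; within the scatter). Compound 3 is estimated at 1600 nM, within 400 nM to 6500 nM.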

Compound 3, half-maximal inhibitory concentration: 1260 nM
For compound 3 the middle estimate is 1.3-fold (0.10 log units) above the measured one; low and high end bracket the measured number.
By their numbers in this assay, from the lowest: compound 1; then compounds 2 and 3 (each within the scatter of the next).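

In this assay, the change from an oxygen-containing ring to a carbon-only ring gives no change at the digits printed from compound 2 to compound 3 (within the scatter), while a 50-fold higher number from compound 1 to compound 3 (1.70 log units; beyond the scatter) matches the loss seen with 1-benzofuran-2-yl. At this place, on a saturated chain carbon bound to an amine nitrogen in a ring, compound 1 with its 1H-indol-2-yl group thus stands apart from both other compounds. No measurement shown gives a reason for this.

The compounds leave open whether the hydrogen on the indole nitrogen is what separates compound 1 from the other two. A 1-methylindol-2-yl or benzimidazol-2-yl group at this place would bear on that.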